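Acetamido in Place of Hydroxy on the Cyclohexyl Ring

The source may report more compounds than this note shows. Statements on the series, on what has been measured and on what is new or still open speak of the compounds shown alone.

Measured compounds:
compound 1, `O=C(OC1CCC(CN2CCN(c3cc(=O)c4cc(C(F)(F)F)cc([N+](=O)[O-])c4s3)CC2)CC1)C1CCCCC1`, 2.8%
compound 2, `O=C(OC1CCC(CN2CCN(c3cc(=O)c4cc(C(F)(F)F)cc([N+](=O)[O-])c4s3)CC2)CC1)c1ccco1`, 1%
compound 3, `O=c1cc(N2CCN(CC3CCC(O)CC3)CC2)sc2c([N+](=O)[O-])cc(C(F)(F)F)cc12`, 72.7%

In an ADME assay on cells (Hepatocyte, Homo sapiens) for metabolic stability, with a stated time of 30 min (on this read-out higher numbers stand for a more stable compound and lower numbers for a less stable compound), compound 3 stands highest of the three, as seen in a number 69.9 percentage points higher from compound 1 to compound 3 (beyond the scatter) and a number 71.7 percentage points higher from compound 2 to compound 3 (beyond the scatter), while a number 1.8 percentage points lower from compound 1 to compound 2 (within the scatter). Compound 4, `CC(=O)NC1CCC(CN2CCN(c3cc(=O)c4cc(C(F)(F)F)cc([N+](=O)[O-])c4s3)CC2)CC1`, differs from compound 3 by acetamido in place of hydroxy on a saturated ring carbon. Within the data shown here, none of the measured steps compares acetamido with hydroxy; the two large steps both concern the removal of a carbonyl-bearing group from the oxygen, and compound 4 keeps no such ester. The account therefore rests on compound 3 alone, with wide uncertainty. Compound 4 is expected to give 55% in this assay, within 20% to 85%, an estimated change of a number 17.7 percentage points lower from compound 3 to compound 4 (beyond the scatter).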

Compound 4, percent of the compound remaining: 86.8%
Compound 4: middle estimate off by 31.8 percentage points, on the low side; the measured number lies above the stated range.
By their numbers in this assay, from the lowest: compounds 2 and 1 (each within the scatter of the next); then compound 3; then compound 4.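

On the 4-acetamidocyclohexyl side chain, this ring position takes an amide in place of the free hydroxy without loss in this assay, as shown by a number 14.1 percentage points higher from compound 3 to compound 4 (beyond the scatter) and not merely by a number held level. The earlier compounds shown here paired a carbonyl-bearing group at this position only with low numbers, yet acetamido stands far above both esters in a number 85.8 percentage points higher from compound 2 to compound 4 (beyond the scatter) and in a number 84 percentage points higher from compound 1 to compound 4 (beyond the scatter) and so a carbonyl-bearing group here need not go with a low number. Nothing measured here accounts for these differences.

From the compounds shown here alone, whether a plain amine, a carboxylic acid or a longer acyl chain on the nitrogen would stand with acetamido or with the esters remains open.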